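Working notes: aryl exchange on an amide-type nitrogen

This account rests on a few compounds, and the source may have more. Where it says the series, first, only, none or still open, it means among the compounds named here.

In a functional assay on MDA-MB-231 cells (Homo sapiens) for antiproliferative activity, read by MTT assay, with a stated time of 48 h (a lower number here means a stronger inhibitor, a higher number a weaker inhibitor), compound 2 `CN1CCN(c2ccc(-c3cc4c(N5CCN(C(=O)Nc6ccc(F)cc6F)CC5)ncnc4s3)cc2)CC1` reads 11400 nM and compound 1 `COc1ccc(NC(=O)N2CCN(c3ncnc4sc(-c5ccc(N6CCN(C)CC6)cc5)cc34)CC2)cc1` reads 20900 nM so the two cannot be separated. The change to compound 3 `CC(C)c1cccc(C(C)C)c1NC(=O)N1CCN(c2ncnc3sc(-c4ccc(N5CCN(C)CC5)cc4)cc23)CC1` is 2,6-diisopropylphenyl in place of 2,4-difluorophenyl on an amide-type nitrogen with the shared core untouched. For the measured compounds named here, the one measured step on that nitrogen is a 1.8-fold lower number from compound 1 to compound 2 (0.26 log units; within the scatter) and it gives no ground for expecting a step beyond the scatter, though it covers a different pair of aryl groups. The expected step is a 1.3-fold higher number from compound 2 to compound 3 (0.12 log units; within the scatter) and it is estimated to stay within the scatter. For compound 3 the estimate is 15000 nM with an expected range from 5000 nM to 40000 nM in this series.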

Compound 3, half-maximal inhibitory concentration: 8430 nM
Compound 3: middle estimate off by 1.8-fold (0.25 log units), on the high side, and the stated range covers the measured number.
By their numbers in this assay, from the lowest: compounds 3, 2 and 1 (each within the scatter of the next, the first and the last beyond it).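

In this assay the exchange of 2,4-difluorophenyl for 2,6-diisopropylphenyl gives a 1.4-fold lower number from compound 2 to compound 3 (0.13 log units; within the scatter) on the amide-type nitrogen, so going from 8 to 12 heavy atoms in this group leaves the two compounds unseparated. For the compounds shown here, measured against 4-methoxyphenyl, the same group gives a 2.5-fold lower number from compound 1 to compound 3 (0.39 log units; beyond the scatter) as the first step at this nitrogen to pass the scatter, though only a modest one. Nothing available bears on a cause for these steps.

All three groups shown are a six-membered aromatic ring of carbon only. As far as these compounds go, how a cyclohexyl group or a phenyl group carrying a carboxylic acid would read at this nitrogen remains open.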